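The compounds below may be only part of what the source reports. "The series", "measured", "known", "first", "only" and "open" are said of these compounds alone.

Measured so far:
compound 1, `CC1(C)CCC(C)(C)c2cc(NC(=O)c3ccc(C(=O)NCC(=O)OCc4c(-c5ccccc5)no[n+]4[O-])cc3)ccc21`: 160 nM
compound 2, `CC1(C)CCC(C)(C)c2cc(NC(=O)c3ccc(C(=O)OCCCCCOC(=O)c4ccc(OCc5c(-c6ccccc6)no[n+]5[O-])cc4)cc3)ccc21`: 282000 nM

Two compounds of this series have been run in a functional assay on HL-60 cells (Homo sapiens) for antiproliferative activity, read by MTT assay, with a stated time of 48 h; on this read-out lower numbers stand for stronger inhibition and higher numbers for weaker inhibition. Compound 1 stands lowest of the two numbers, with 160 nM. Compound 2 gives 282000 nM, a much higher number; the gap between the two is far beyond the scatter, so compound 1 is the more potent of the pair. Nothing else connects the two, since no single-point change links them.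

The next compound, compound 3, `CC(C)C[C@H](NC(=O)c1ccc(C(=O)Nc2ccc3c(c2)C(C)(C)CCC3(C)C)cc1)C(=O)OCc1c(-c2ccccc2)no[n+]1[O-]`, differs from compound 1 in one place: isobutyl in place of hydrogen on a saturated chain carbon bound to an amide-type nitrogen and a carbonyl carbon. The rest of the molecule, the shared core and the ring-bearing ester end, is unchanged. Among the compounds with values here, no measured pair tests a change of this kind, so there is no precedent to lean on.

Given that compound 1 gives 160 nM and the change leaves the ester and amide linkage intact, the expected step from compound 1 to compound 3 is small, a 1.3-fold higher number from compound 1 to compound 3 (0.10 log units; within the scatter), likely not beyond the scatter in either direction. Compound 3 is therefore estimated at 200 nM, within a range of 50 nM to 800 nM.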

Compound 3, half-maximal inhibitory concentration: 740 nM
Estimate against measurement, compound 3: 3.7-fold (0.57 log units) below, and the stated range covers the measured number.
By their numbers in this assay, from the lowest: compound 1; then compound 3; then compound 2.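

In this assay, within the data shown here, the saturated chain carbon bound to an amide-type nitrogen and a carbonyl carbon is the first place where a single change can be read. Isobutyl in place of hydrogen there gives a 4.6-fold higher number from compound 1 to compound 3 (0.67 log units; beyond the scatter) as a modest step, so this carbon is sensitive to substitution, yet the addition of 4 heavy atoms, with no ring and no hydrogen-bond donors or acceptors, does not abolish activity: compound 3 still reads 740 nM in this series. Nothing available bears on why the number rises at this position.

The compounds shown leave open how the number moves with other groups on the same carbon, such as methyl, benzyl, or a chain ending in a carboxylic acid or an amine, so one step gives no trend with chain length or branching. They also leave open whether the opposite configuration at that carbon would give a similar number to compound 3 or one closer to that of compound 1.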